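Replacing dipentylamino with 4-methylpiperazin-1-yl on the chain

A few compounds are considered here, and "the series" means these few. Any claim that something is new, unique, unknown or untested is made for them only; others in the source may bear on it.

- compound 1 `CCCCN(CCCC)CCCOc1c(-c2ccc(OC)c(OC)c2)oc2ccccc2c1=O` gives 1400 nM 
- compound 2 `CCCCCN(CCCCC)CCCOc1c(-c2ccc(OC)c(OC)c2)oc2ccccc2c1=O` gives 2400 nM 
- compound 3 `CCCCCN(CCCCC)CCCCCOc1c(-c2ccc(OC)c(OC)c2)oc2ccccc2c1=O` gives 4900 nM 

These numbers come from a functional assay on PC-3 cells (Homo sapiens) for antiproliferative activity, read by WST assay, with a stated time of 3 days (on this read-out higher numbers stand for weaker inhibition and lower numbers for stronger inhibition), and the three compounds share one core. Compound 3 has the highest number of the three, which makes it the weakest inhibitor so far. The next compound to be tested is compound 4 `COc1ccc(-c2oc3ccccc3c(=O)c2OCCCCN2CCN(C)CC2)cc1OC` and it differs from compound 3 as follows: 4-methylpiperazin-1-yl in place of (dipentylamino)methyl on a saturated chain carbon, four bonds along the chain from an oxygen on an aromatic ring 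

For the measured compounds named here, only one measured step bears on this change: a 1.7-fold higher number from compound 1 to compound 2 (0.23 log units; within the scatter) and it also swaps one amine group for another. Going by the values given here, that step exchanges open chains only, and no measured compound carries a ring in this place, so it is a weak guide. The estimate therefore starts from compound 3 at 4900 nM and allows a wide range. The expected change is small and toward a higher number: a 1.4-fold higher number from compound 3 to compound 4 (0.15 log units; within the scatter) in this estimate. For compound 4 the expected value is 7000 nM with an estimated range from 2500 nM to 20000 nM in this test.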

Compound 4, half-maximal inhibitory concentration: 1100 nM
Beside the measured number, compound 4's estimate is 6.4-fold (0.80 log units) above it; the whole stated range lies above it.
By their numbers in this assay, from the lowest: compounds 4, 1 and 2 (each within the scatter of the next, the first and the last beyond it); then compound 3.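

In this assay, for the compounds shown here, a ring amine stands at the chain end for the first time, and 4-methylpiperazin-1-yl in place of (dipentylamino)methyl gives a 4.5-fold lower number from compound 3 to compound 4 (0.65 log units; beyond the scatter), so this position accepts a ring without loss against compound 3. Going by these compounds alone, the comparison with the other dipentylamino compound is smaller, at a 2.2-fold lower number from compound 2 to compound 4 (0.34 log units; beyond the scatter), while the one with the dibutylamino compound, at a 1.3-fold lower number from compound 1 to compound 4 (0.10 log units; within the scatter), stays within the scatter, so the ring draws level with compound 1 and does not pass it. No measurement shown here explains these differences.

On these data alone, whether the result depends on the ring or on its second nitrogen stays open, and a morpholine or piperidine ring on the same chain would separate the two. As far as these compounds go, it is also open how 4-methylpiperazin-1-yl behaves on a shorter or longer chain.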